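The source may hold more compounds than are shown below. What is called first, only, known or untested is meant among the compounds shown, and "the series" means these compounds.

- Compound 1 `CN1C/C(=C\c2cccnc2)C(=O)/C(=C/c2ccccc2F)C1`: 4470 nM
- Compound 2 `O=C1/C(=C/c2cccnc2)CN(S(=O)(=O)c2ccc(Br)cc2)C/C1=C\c1ccccc1F`: 12800 nM

Both values come from a functional assay on QGY-7703 cells (Homo sapiens) for cytotoxicity, read by MTT assay, with a stated time of 24 h; a lower number here means a stronger inhibitor, a higher number a weaker inhibitor. Of the two, compound 2 has the higher number at 12800 nM, which makes it the weaker inhibitor of this small pair. The next compound to be tested is compound 3 `N#Cc1ccc(S(=O)(=O)N2C/C(=C\c3cccnc3)C(=O)/C(=C/c3ccccc3F)C2)cc1`, which differs from compound 2 in one place: cyano in place of bromo on an aromatic carbon. In words, cyano replaces bromo on an aromatic carbon, and the rest of the molecule stays the same.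

Among the compounds with values here, no measured step makes this exact exchange, so the evidence is indirect. Within the data shown here, the only measured step is a 2.9-fold higher number from compound 1 to compound 2 (0.46 log units; beyond the scatter), a modest change that came from replacing the whole methyl group on the ring nitrogen with (4-bromophenyl)sulfonyl. The new change alters only one substituent within that larger group, so a step of that size seems unlikely, and none beyond the scatter is expected in this assay. The expected change is a 1.3-fold lower number from compound 2 to compound 3 (0.11 log units; within the scatter). For compound 3 the estimate is 10000 nM, with an expected range from 4500 nM to 22000 nM.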

Compound 3, half-maximal inhibitory concentration: 15800 nM
Compound 3: middle estimate off by 1.6-fold (0.20 log units), on the low side; the measured number falls inside the stated range.
By their numbers in this assay, from the lowest: compound 1; then compounds 2 and 3 (each within the scatter of the next).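

In this assay, placing cyano where bromo stood, on an aromatic carbon para to a large group, gives a 1.2-fold higher number from compound 2 to compound 3 (0.09 log units; within the scatter) and so stays within the scatter: at this position, these two groups cannot be told apart. Replacing methyl on the ring nitrogen with (4-cyanophenyl)sulfonyl gives a 3.5-fold higher number from compound 1 to compound 3 (0.55 log units; beyond the scatter) and, like the earlier step of a 2.9-fold higher number from compound 1 to compound 2 (0.46 log units; beyond the scatter) with (4-bromophenyl)sulfonyl, lies beyond the scatter, so the gap from compound 1 no longer rests on a single sulfonyl compound and survives this exchange at the far end of the group. Nothing among the data offers an explanation for either observation.

Two substituents that read alike say little about this position in general, so an amine or a carboxylic acid on the same aromatic carbon could still behave quite differently. From the compounds shown here alone, it also remains open which part of the larger group on the ring nitrogen goes with the gap from compound 1, a question that a plain phenylsulfonyl group or an acetyl group at that nitrogen would bear on.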